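This account rests on a few compounds, and the source may have more. Where it says the series, first, only, none or still open, it means among the compounds named here.

Compound 1 `CCC[C@@H](CCO)Nc1nc(N)nc(C)c1Cc1ccc(CNC2CNC2)cc1OC` gives > 10000 nM in an assay on HEK293 cells for agonist activity at Toll-like receptor 8 (Homo sapiens) (a lower number here means that less compound is needed, a higher number that more compound is needed for the effect), which is a limit of the assay and not a number. Compound 1 therefore sits at the limit of > 10000 nM in this assay, at which 1 of the 2 values shown sits. Compound 2 `CCC[C@@H](CO)Nc1nc(N)nc(C)c1Cc1ccc(CNCCO)cc1OC` gives 5370 nM in this assay. Compound 3 `CCC[C@@H](CCO)Nc1nc(N)nc(C)c1Cc1ccc(CNCCC(N)=O)cc1OC` differs from compound 1 by 2-carbamoylethyl in place of azetidin-3-yl on an amine nitrogen. For the measured compounds named here, no measured pair covers this change, and compound 1 itself has only a limit, so the direction of the step is open. The step is expected to be an at least 1.1-fold lower number from compound 1 to compound 3 (0.04 log units; that floor lies within the scatter), no larger than the scatter. Compound 3 is estimated at 9000 nM, with a range from 2500 nM to 30000 nM.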

Compound 3, half-maximal effective concentration: > 10000 nM
Compound 3: no number, only a limit; the forecaster's own chance of this, stated with the estimate: 50%; at least 1.1-fold (0.04 log units) between middle value and limit.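

Compound 1 and compound 3 both sit at a limit of the assay rather than at a number, so no step between them can be read: the limit of > 10000 nM in this assay, at which 2 of the 3 values shown sit.

The compounds shown leave open whether azetidin-3-yl or 2-carbamoylethyl on the amine nitrogen gives the lower number in this assay.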